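A few compounds are considered here, and "the series" means these few. Any claim that something is new, unique, unknown or untested is made for them only; others in the source may bear on it.

Measured in a functional assay on U2OS cells (Homo sapiens) for cytotoxicity, read by MTT assay, with a stated time of 48 h; a lower number here means a stronger inhibitor, a higher number a weaker inhibitor; each entry is a limit, not a number:
- compound 1 `COc1ccccc1Nc1nc(-c2cccc(F)c2)nc2ccc(F)cc12`: > 50000 nM
- compound 2 `Fc1ccc(Nc2nc(-c3cccc(F)c3)nc3ccc(F)cc23)cc1`: > 50000 nM
- compound 3 `Oc1ccc(Nc2nc(-c3cccc(F)c3)nc3ccc(F)cc23)cc1`: > 50000 nM

The position of compound 3 is not a ranked one. Compound 3 gives > 50000 nM, which is a limit. The same holds across the set: the limit of > 50000 nM in this assay, at which 3 of the 3 values shown sit.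

Compound 4 `Nc1ccc(Nc2nc(-c3cccc(F)c3)nc3ccc(F)cc23)cc1` has not been measured. It differs from compound 3 by amino in place of hydroxy on an aromatic carbon, para to a large group.

The closest measured change at this carbon is a step that the two limits leave unreadable from compound 2 to compound 3. The two changes to the whole aryl group are a step that the two limits leave unreadable from compound 1 to compound 2 and a step that the two limits leave unreadable from compound 1 to compound 3. None of these gives a size, so the data offer no measured basis for a shift in this assay. The working expectation is therefore no clear step, and another report of only a limit is the most likely outcome for compound 4. Any readable value would have to fall on the stronger side of the limit, so the range extends in that direction.

For compound 4 the estimated value is 40000 nM, with an expected range of 10000 nM to 80000 nM. The expected change is an at least 1.2-fold lower number from compound 3 to compound 4 (0.09 log units; that floor lies within the scatter).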

Compound 4, half-maximal inhibitory concentration: 44200 nM
Estimate against measurement, compound 4: 1.1-fold (0.04 log units) below, and the stated range covers the measured number.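

In this assay, among the compounds shown here, compound 4 gives 44200 nM, the first number at this position that is not a limit, with amino on an aromatic carbon, para to a large group. Against the earlier compounds the change reads as an at least 1.1-fold lower number from compound 3 to compound 4 (0.05 log units; that floor lies within the scatter), as an at least 1.1-fold lower number from compound 2 to compound 4 (0.05 log units; that floor lies within the scatter) and as an at least 1.1-fold lower number from compound 1 to compound 4 (0.05 log units; that floor lies within the scatter), so each of these is only a floor, each floor lies within the scatter, and no real gain can be claimed from amino. The steps among compound 1, compound 2 and compound 3 still cannot be read, and the set remains held mostly at one limit: the limit of > 50000 nM in this assay, at which 3 of the 4 values shown sit.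

From the compounds shown here alone, whether amino differs from hydroxy or fluoro at this carbon by more than the scatter remains open. Also open, going by these compounds, is whether a dimethylamino group, an acetamide or an aminomethyl group on the same carbon would give a readable number, and how far such a number would lie from that of compound 4.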